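The compounds below may be only part of what the source reports. "The series", "measured", "known", "first", "only" and "open" are said of these compounds alone.

Measured in a functional assay on A549 cells (Homo sapiens) for cytotoxicity, read by resazurin assay, with a stated time of 72 h; on this read-out lower numbers stand for stronger inhibition and higher numbers for weaker inhibition:
- Compound 1 `N#Cc1cc(-c2ccccc2)n(-c2cccc(Br)c2)c1N`: 13000 nM
- Compound 2 `Nc1c(-c2nc3ccccc3[nH]2)cc(-c2ccccc2)n1-c1cccc(Br)c1`: 13500 nM

In this assay, compound 2 stands level with compound 1, as their two values lie within the usual scatter of repeated measurements. Compound 3 `Nc1c(-c2nc3ccccc3[nH]2)cc(-c2ccccc2)n1-c1nc2ccccc2[nH]1` keeps the rest of compound 2 but carries 1H-benzimidazol-2-yl in place of 3-bromophenyl on an aromatic nitrogen. Among the compounds with values here, only one measured step bears on this change, and only loosely. That step, a 1.0-fold higher number from compound 1 to compound 2 (0.02 log units; within the scatter), put the same 1H-benzimidazol-2-yl group on an aromatic carbon in place of cyano, and it stayed within the scatter. Within the data shown here, no measured pair shows a change on the aromatic nitrogen, so the guide is weak and no direction can be argued. In this assay, I therefore expect no step beyond the scatter, though with wide uncertainty. The estimated step is a 1.1-fold lower number from compound 2 to compound 3 (0.05 log units; within the scatter). For compound 3 the expected value is 12000 nM, with an estimated range of 3000 nM to 45000 nM.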

Compound 3, half-maximal inhibitory concentration: 7700 nM
Beside the measured number, compound 3's estimate is 1.6-fold (0.19 log units) above it, and the stated range covers the measured number.
By their numbers in this assay, from the lowest: compounds 3, 1 and 2 (each within the scatter of the next).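

In this assay, within the data shown here, the change on the aromatic nitrogen gives a 1.8-fold lower number from compound 2 to compound 3 (0.24 log units; within the scatter), the first measured step at this position, since the step from compound 1 to compound 2 concerned an aromatic carbon. Compound 3 therefore shows that 3-bromophenyl can give way to 1H-benzimidazol-2-yl, which has more heavy atoms, no bromine, an added five-membered aromatic ring, and a hydrogen-bond donor and acceptor, with the two compounds still level in this read-out. No measurement available here accounts for this result.

From the compounds shown here alone, what remains open is whether a much smaller group on that nitrogen, such as methyl, would also leave the number within the scatter. A group of another kind, such as a carboxylic acid on a short chain, is equally untested in the compounds shown.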